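A few compounds are considered here, and "the series" means these few. Any claim that something is new, unique, unknown or untested is made for them only; others in the source may bear on it.

Measured in a functional assay on HeLa cells (Homo sapiens) for inhibition, with a stated time of 72 h; on this read-out higher numbers stand for an effect only at larger amounts of compound and lower numbers for an effect already at smaller amounts
- compound 1 (`COc1cc(CNCCCN(C)C)ccc1OCc1ccc(Cl)nc1`) gives 5000 nM
- compound 2 (`COc1cc(CNCc2ccncc2)ccc1OCc1ccc(Cl)nc1`) gives 400 nM
- compound 3 (`COc1cc(CNCc2cccnc2)ccc1OCc1ccc(Cl)nc1`) gives 5000 nM

Compound 3 stands level with compound 1, the two sharing the highest of the three numbers, and well away from compound 2 (a 13-fold higher number from compound 2 to compound 3 (1.10 log units; beyond the scatter)). Compound 4 (`COc1cc(CNCC2CCCO2)ccc1OCc1ccc(Cl)nc1`) carries oxolan-2-yl in place of pyridin-3-yl on a saturated chain carbon bound to an amine nitrogen. For the measured compounds named here, three measured steps bear on this place. Exchanging 2-(dimethylamino)ethyl for pyridin-3-yl left the number unchanged (no change at the digits printed from compound 1 to compound 3 (within the scatter)). Only pyridin-4-yl in compound 2 gave a large step (a 13-fold lower number from compound 1 to compound 2 (1.10 log units; beyond the scatter)). Going by the values given here, compound 4 does not carry that group, and no compound with oxolan-2-yl has been measured yet. In this assay no step beyond the scatter is therefore expected, with no firm direction. The expected step stays small (a 1.3-fold lower number from compound 3 to compound 4 (0.10 log units; within the scatter)) and is only an estimate. Compound 4 is estimated at 4000 nM within an expected range from 1300 nM to 10000 nM for such a measurement.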

Compound 4, half-maximal effective concentration: 66000 nM
Estimate against measurement, compound 4: 17-fold (1.22 log units) below; the measured number lies above the stated range.
By their numbers in this assay, from the lowest: compound 2; then compounds 1 and 3 (each within the scatter of the next); then compound 4.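

In this assay, the position on a saturated chain carbon bound to an amine nitrogen can also push the number well above the level shared by compound 1 and compound 3: oxolan-2-yl in place of pyridin-3-yl gives one large step (a 13-fold higher number from compound 3 to compound 4 (1.12 log units; beyond the scatter)), and in place of 2-(dimethylamino)ethyl another (a 13-fold higher number from compound 1 to compound 4 (1.12 log units; beyond the scatter)). Measured against pyridin-4-yl, the same group gives the widest step of the series (a 170-fold higher number from compound 2 to compound 4 (2.22 log units; beyond the scatter)), so this position tolerates far less variation than the unchanged pair of compound 1 and compound 3 suggested. No measurement on hand explains these steps.

This change alters ring size, aromatic character and the hetero atom together, and the four compounds do not separate these. Open, as far as these compounds go, is where a phenyl ring, pyridin-2-yl or oxan-2-yl would fall at this position.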